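This account rests on a few compounds, and the source may have more. Where it says the series, first, only, none or still open, it means among the compounds named here.

Compound 1 `Cc1cccc(-n2nncc2CN2C(=O)C3(C(C#N)=C(N)Oc4c(N)cc5nc6ccccc6nc5c43)c3ccccc32)c1`, in an ADME assay on HUVEC cells (Homo sapiens) for antiproliferative activity, read by MTT assay, with a stated time of 48 h (on this read-out higher numbers stand for weaker inhibition and lower numbers for stronger inhibition), reported only as the limit > 50000 nM.
Compound 2 `N#CC1=C(N)Oc2c(N)cc3nc4ccccc4nc3c2C12C(=O)N(Cc1cnnn1-c1cccc(C(F)(F)F)c1)c1ccccc12`, in this assay reported only as the limit > 50000 nM.

Compound 2 stands at the limit where both measured values sit (the limit of > 50000 nM in this assay, at which 2 of the 2 values shown sit). The change from compound 2 to compound 3 `CCOc1ccccc1-n1nncc1CN1C(=O)C2(C(C#N)=C(N)Oc3c(N)cc4nc5ccccc5nc4c32)c2ccccc21` is 2-ethoxyphenyl in place of 3-(trifluoromethyl)phenyl on an aromatic nitrogen. Among the measured compounds shown here, the one measured step, a step that the two limits leave unreadable from compound 1 to compound 2, also exchanges a group on an aromatic nitrogen, and because both of its ends rest at the limit of > 50000 nM in this assay, at which 2 of the 2 values shown sit, its size cannot be read. Compound 3 is therefore expected to give 80000 nM, within 20000 nM to 300000 nM, most likely reported once more as a limit. The step that the limit leaves unreadable from compound 2 to compound 3 is the expected change, none beyond the scatter.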

Compound 3, half-maximal inhibitory concentration: > 50000 nM
Compound 3 ended at the assay's limit (the forecaster's own chance of this, stated with the estimate: 80%); the middle value is on the limit's open side.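

Among the compounds shown here, no step between compound 1, compound 2 and compound 3 can be read in this assay, because each is reported only as a limit: the limit of > 50000 nM in this assay, at which 3 of the 3 values shown sit.
The compounds shown leave open whether these three groups on the aromatic nitrogen differ at all in this assay.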